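Swapping an aromatic ring for a saturated one at the pyridine

The source may report more compounds than this note shows. Statements on the series, on what has been measured and on what is new or still open speak of the compounds shown alone.

Compound 2, with the structure `COc1nc(-c2ccccc2F)ccc1[C@@H](c1ccccc1)[C@@](O)(CCN(C)C)c1cccc2ccccc12`, was tested in a toxicity assay on Vero cells (Chlorocebus sabaeus) for cytotoxicity; a higher number here means that more compound is tolerated, a lower number that less compound is tolerated. In this assay compound 2 shows only the limit > 50 ug/mL, so no exact number is known for it. The related compound 1, with the structure `COc1ncc(-c2ccccc2)cc1[C@@H](c1ccccc1)[C@@](O)(CCN(C)C)c1ccccc1`, likewise reaches only the limit > 50 ug/mL in this assay. Both values therefore rest at the limit of > 50 ug/mL in this assay, at which 2 of the 2 values shown sit.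

Compound 3, with the structure `COc1nc(C2CCCCC2)ccc1[C@@H](c1ccccc1)[C@@](O)(CCN(C)C)c1cccc2ccccc12`, has not yet been tested. It differs from compound 2 in one place: cyclohexyl in place of 2-fluorophenyl on an aromatic carbon. Both compounds seen so far sit at the limit, and nothing measured here distinguishes an aromatic from a saturated ring at this position. The step expected from compound 2 to compound 3 is therefore a step that the limit leaves unreadable from compound 2 to compound 3, none beyond the scatter. Compound 3 is expected to give about 60 ug/mL, within a range from 30 ug/mL to 150 ug/mL, most likely again only as a limit.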

Compound 3, half-maximal cytotoxic concentration: 32.3 ug/mL
Estimate against measurement, compound 3: 1.9-fold (0.27 log units) above; the range from low to high includes it.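

In this assay, cyclohexyl in place of 2-fluorophenyl gives the first exact reading among the compounds shown, and the change comes with an at least 1.5-fold lower number from compound 2 to compound 3 (0.18 log units; that floor lies within the scatter). This position can therefore carry a saturated ring and still give a value inside the readable range, but this floor alone does not show a real drop in tolerated compound. The true size of the step cannot be fixed because compound 2 gives only a limit: the limit of > 50 ug/mL in this assay, at which 2 of the 3 values shown sit.

The change removes the aromatic ring and the fluorine together, so the compounds shown do not separate the two; a fluorocyclohexyl group at this position would keep the fluorine on a saturated ring. From the compounds shown here alone, how a ring carrying a nitrogen, such as piperidine, or an open hexyl chain would fare here also remains open.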